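This account rests on a few compounds, and the source may have more. Where it says the series, first, only, none or still open, it means among the compounds named here.

Measured so far in a functional assay on K562 cells (Homo sapiens) for inhibition, with a stated time of 72 h; a lower number here means a stronger inhibitor, a higher number a weaker inhibitor:
- compound 1 `NC1CCC(Nc2nc(NCc3ccc(Br)cc3)c3ncn(C4CCCC4)c3n2)CC1`: 1170 nM
- compound 2 `NC1CCC(Nc2nc(NCc3ccc(-c4ccco4)cc3)c3ncn(C4CCCC4)c3n2)CC1`: 96 nM
- compound 3 `NC1CCC(Nc2nc(NCc3ccc(-c4ccsc4)cc3)c3ncn(C4CCCC4)c3n2)CC1`: 150 nM

The number for compound 3 cannot be separated from that of the furan-2-yl member of the series: a 1.6-fold higher number from compound 2 to compound 3 (0.19 log units; within the scatter). The bromo member stands clearly apart: a 7.8-fold lower number from compound 1 to compound 3 (0.89 log units; beyond the scatter).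

Compound 4 `NC1CCC(Nc2nc(NCc3ccc(-c4ccccc4O)cc3)c3ncn(C4CCCC4)c3n2)CC1` keeps the shared core and carries 2-hydroxyphenyl in place of thiophen-3-yl on an aromatic carbon, para to a large group: 2-hydroxyphenyl in place of thiophen-3-yl on an aromatic carbon.

Two kinds of measured step bear on this change. Replacing bromo with an aromatic ring gave a 12-fold lower number from compound 1 to compound 2 (1.09 log units; beyond the scatter), alongside the step to compound 3 already noted. Exchanging one aromatic ring for another is the closer precedent, and it gave only a 1.6-fold higher number from compound 2 to compound 3 (0.19 log units; within the scatter). Going by the values given here, the change to compound 4 is of this second kind, although no measured compound carries a six-membered ring or a hydroxyl group at this place, so the range has to stay wide.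

In this assay, no step beyond the scatter is therefore expected, and the estimated step is a 1.2-fold lower number from compound 3 to compound 4 (0.06 log units; within the scatter). The estimate for compound 4 is 130 nM, with an expected range of 40 nM to 450 nM.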

Compound 4, half-maximal inhibitory concentration: 2610 nM
For compound 4 the middle estimate is 20-fold (1.30 log units) below the measured one; the whole stated range lies below it.
By their numbers in this assay, from the lowest: compounds 2 and 3 (each within the scatter of the next); then compound 1; then compound 4.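

In this assay this position does not treat all aromatic rings alike: 2-hydroxyphenyl, on the aromatic carbon para to a large group, gives up what thiophen-3-yl (a 17-fold higher number from compound 3 to compound 4 (1.24 log units; beyond the scatter)) and furan-2-yl (a 27-fold higher number from compound 2 to compound 4 (1.43 log units; beyond the scatter)) had gained over bromo. Compound 4 even ends up weaker than the bromo member (a 2.2-fold higher number from compound 1 to compound 4 (0.35 log units; beyond the scatter)), so it goes against the reading from compounds 2 and 3 that an aromatic ring in place of bromo lowers the number, and an aromatic ring here is not sufficient on its own for a low number. The data at hand offer no explanation for this loss.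

The entering group differs from the five-membered rings both as a six-membered aromatic ring of carbon only and in carrying a hydroxyl, and the compounds shown cannot tell which of the two goes with the step. A plain phenyl ring would speak to the ring alone, while 2-methoxyphenyl or 2-aminophenyl would show whether the outcome depends on the hydroxyl itself.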